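The source may report more compounds than this note shows. Statements on the series, on what has been measured and on what is new or still open speak of the compounds shown alone.

Three compounds of this series carry a measured number. Compound 1 `CCOC(=O)c1cnn(-c2nc(-c3ccccc3F)c(C#N)c(=O)n2C)c1N` gives in a functional assay, with a stated time of 10 min (a lower number here means a stronger inhibitor, a higher number a weaker inhibitor), a value of 86 ug/mL. Compound 2 `COc1cccc(-c2nc(NN)n(C)c(=O)c2C#N)c1OC` gives in this assay a value of 36 ug/mL, and compound 3 `Cn1c(NN)nc(-c2cccs2)c(C#N)c1=O` gives 53 ug/mL. Of the three numbers, that of compound 1 is the highest, though it lies within the scatter of compound 3 and stands apart only from compound 2, which is the stronger inhibitor of that pair. Compound 4 `CCOC(=O)c1cnn(-c2nc(-c3ccccc3Cl)c(C#N)c(=O)n2C)c1N` differs from compound 1 in one place: chloro in place of fluoro on an aromatic carbon. Among the compounds with values here, no measured pair shows this change, so the expectation rests on the change alone. The step from compound 1 to compound 4 in this assay is expected to be small, a 1.2-fold lower number from compound 1 to compound 4 (0.09 log units; within the scatter), not beyond the scatter in either direction. Compound 4 is estimated at 70 ug/mL, with a range of 30 ug/mL to 160 ug/mL.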

Compound 4, half-maximal inhibitory concentration: 98 ug/mL
Beside the measured number, compound 4's estimate is 1.4-fold (0.15 log units) below it, within the range that was stated.
By their numbers in this assay, from the lowest: compounds 2, 3, 1 and 4 (each within the scatter of the next, the first and the last beyond it).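

Within the data shown here, the first matched pair is 2-fluorophenyl to 2-chlorophenyl, and in this assay it reads a 1.1-fold higher number from compound 1 to compound 4 (0.06 log units; within the scatter), within the scatter. On this aromatic carbon, ortho to a large group, the two halogens therefore cannot be told apart by this read-out, at least on the core of compound 1. Nothing at hand accounts for this result.

On these data alone, it remains open whether a non-halogen group at this place, such as a hydroxyl or a carboxylic acid, would shift the number beyond the scatter. Whether the same exchange reads alike on the other compounds of the series is also unsettled.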